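A few compounds are considered here, and "the series" means these few. Any claim that something is new, unique, unknown or untested is made for them only; others in the source may bear on it.

Measured so far:
compound 1 `CCCCCN(CCCCC)C(=O)N1CCN(C(=O)N(c2ccccc2)c2ccccc2)[C@H](C(=O)NCCN(C)C)C1` — 55 nM
compound 2 `CCCCCN(CCCCC)C(=O)N1CCN(C(=O)N(c2ccccc2)c2ccccc2)[C@H](C(=O)NCCN(CC)CC)C1` — 11 nM

Within the data shown here, in an assay on CHO cells for binding affinity to Substance-P receptor (Homo sapiens) (a higher number here means a weaker inhibitor, a lower number a stronger inhibitor), compound 2 stands with the lowest number of the two, the only neighbour being compound 1, reached over a 5.0-fold lower number from compound 1 to compound 2 (0.70 log units; beyond the scatter). Compound 3 `CCCCCN(CCCCC)C(=O)N1CCN(C(=O)N(c2ccccc2)c2ccccc2)[C@H](C(=O)NCCCN(CC)CC)C1` differs from compound 2 by (diethylamino)methyl in place of diethylamino on a saturated chain carbon, two bonds along the chain from an amide-type nitrogen. Among the measured compounds shown here, the one measured step, from compound 1 to compound 2, concerns the substituents on the amine nitrogen and not the length of the chain that carries it, so no measured step bears directly on this change; it is noted only as a modest step. For the change into compound 3 no step beyond the scatter is expected in either direction, and compound 3 is therefore estimated at a 1.1-fold higher number from compound 2 to compound 3 (0.04 log units; within the scatter) relative to compound 2. The estimate for compound 3 in this assay is 12 nM, with a range from 4 nM to 35 nM.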

Compound 3, half-maximal inhibitory concentration: 41 nM
For compound 3 the middle estimate is 3.4-fold (0.53 log units) below the measured one; the measured number lies above the stated range.
By their numbers in this assay, from the lowest: compound 2; then compounds 3 and 1 (each within the scatter of the next).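

In this assay, the length of the chain carrying the amine proves to matter as well as the substituents on its nitrogen: 3-(diethylamino)propyl in place of 2-(diethylamino)ethyl gives a 3.7-fold higher number from compound 2 to compound 3 (0.57 log units; beyond the scatter). The change from the 2-(dimethylamino)ethyl of compound 1 to the 3-(diethylamino)propyl of compound 3 gives a 1.3-fold lower number from compound 1 to compound 3 (0.13 log units; within the scatter), so the longer diethylamino chain does not hold the advantage that the shorter one shows over dimethylamino. Nothing available accounts for the loss on lengthening the chain.

Still open, on these data alone, is how 3-(dimethylamino)propyl would compare with 2-(dimethylamino)ethyl, which would show whether the effect of chain length depends on the substituents on the nitrogen. Also open, as far as these compounds go, is whether 4-(diethylamino)butyl would continue the trend from compound 2 to compound 3.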